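Exchanging the aryl group on the shared core

This account rests on a few compounds, and the source may have more. Where it says the series, first, only, none or still open, it means among the compounds named here.

In an ADME assay on HEK293 cells (Homo sapiens) for cytotoxicity, read by fluorescence and resazurin assay, with a stated time of 24 h (a lower number here means that less compound is tolerated, a higher number that more compound is tolerated), compound 1 (`COC(=O)c1ccc(-c2nnc(SC3=CS(=O)(=O)c4ccccc43)o2)cc1`) reads 4000 nM and compound 2 (`O=S1(=O)C=C(Sc2nnc(-c3ccccc3Cl)o2)c2ccccc21`) reads 4000 nM at the same level, within the scatter. Compound 3 (`Cc1ccc(-c2nnc(SC3=CS(=O)(=O)c4ccccc43)o2)cc1`) carries 4-methylphenyl in place of 2-chlorophenyl on an aromatic carbon and awaits measurement. Among the compounds with values here, no step between measured compounds exists to size this change. Compound 2 at 4000 nM shows no separation from compound 1 despite a different group on the shared core, so no step beyond the scatter is expected in this assay here. The expected step is no change at the digits printed from compound 2 to compound 3 (within the scatter) on this estimate. For compound 3 the estimated value is 4000 nM (1800 nM to 9000 nM).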

Compound 3, half-maximal cytotoxic concentration: 3000 nM
Compound 3: the middle estimate sits 1.3-fold (0.12 log units) above what was measured; the measured number falls inside the stated range.
By their numbers in this assay, from the lowest: compounds 3, 1 and 2 (each within the scatter of the next).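

In this assay, 4-methylphenyl in place of 2-chlorophenyl gives a 1.3-fold lower number from compound 2 to compound 3 (0.12 log units; within the scatter) and methyl in place of methoxycarbonyl gives a 1.3-fold lower number from compound 1 to compound 3 (0.12 log units; within the scatter). The three aryl groups now shown on this aromatic carbon of the shared core therefore stay within the scatter of each other, and the two steps give this position a first measured size of change. No supporting measurement is available to explain this result.

From the compounds shown here alone, whether an amine or a carboxylic acid on the aryl group would separate from these compounds stays open. So does the effect of a longer chain in place of the aryl group.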